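Dithiocarbamate chromones against LM7 cells: morpholine versus diisopropylamine

The source may hold more compounds than are shown below. What is called first, only, known or untested is meant among the compounds shown, and "the series" means these compounds.

Measured so far:
compound 1 `O=c1c(CSC(=S)N2CCOCC2)coc2cc(Cl)ccc12`: 6200 nM
compound 2 `CC(C)N(C(=S)SCc1cc(=O)c2ccccc2o1)C(C)C`: > 25000 nM
compound 3 `CC(C)N(C(=S)SCc1coc2cc(Cl)ccc2c1=O)C(C)C`: > 25000 nM

In a functional assay on LM7 cells (Homo sapiens) for antiproliferative activity, read by MTT assay, with a stated time of 72 h (a lower number here means a stronger inhibitor, a higher number a weaker inhibitor), compound 1 gives 6200 nM. For compound 2 the value of > 25000 nM is a limit of the assay, not a number. For compound 3 the value of > 25000 nM is likewise a limit. Among the compounds with values here, the one counted step, (morpholin-4-yl in place of diisopropylamino on a thiocarbonyl carbon), gives an at least 4.0-fold lower number from compound 3 to compound 1 (0.60 log units; beyond the scatter); how far it truly reaches is unknown, since the limit of > 25000 nM in this assay, at which 2 of the 3 values shown sit, caps the starting point.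

Compound 4 `O=c1cc(CSC(=S)N2CCOCC2)oc2ccccc12` is not yet measured. It stands to compound 2 as compound 1 stands to compound 3: morpholin-4-yl in place of diisopropylamino on a thiocarbonyl carbon, the same change at the same place. The difference between the core of compound 2 and the core of compound 3 is not broken down here.

Compound 4 is expected to move by about an at least 2.5-fold lower number from compound 2 to compound 4 (0.39 log units; beyond the scatter) from compound 2, resting on the step of an at least 4.0-fold lower number from compound 3 to compound 1 (0.60 log units; beyond the scatter) seen in this assay, though with a limit at the start the size of that step is itself uncertain. The estimate for compound 4 is 10000 nM, within 3000 nM to 25000 nM.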

Compound 4, half-maximal inhibitory concentration: 25200 nM
Beside the measured number, compound 4's estimate is 2.5-fold (0.40 log units) below it; the measured number lies above the stated range.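

No new step can be read from compound 2 to compound 4, because the value for compound 2 is a limit and not a number: the limit of > 25000 nM in this assay, at which 2 of the 4 values shown sit.

The compounds shown leave open whether morpholin-4-yl in place of diisopropylamino on a thiocarbonyl carbon lowers the number at all on the core of compound 2, and how large the change is on the core of compound 3.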